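Swapping a dichlorophenyl for methoxyphenyl on an aminoquinoxaline core

A few compounds are considered here, and "the series" means these few. Any claim that something is new, unique, unknown or untested is made for them only; others in the source may bear on it.

Of the compounds shown here, three sharing one core have been measured in a functional assay on NCI-H322M cells (Homo sapiens) for inhibition, read by sulforhodamine B assay, with a stated time of 48 h; on this read-out lower numbers stand for stronger inhibition of growth and higher numbers for weaker inhibition of growth. Compound 1 `Nc1cc(N)c2nc(-c3ccccc3)c(NCc3ccc(Cl)c(Cl)c3)nc2c1` gives 13500 nM. Compound 2 `Nc1cc(N)c2nc(-c3ccccc3)c(Sc3ccc(F)cc3)nc2c1` gives 20400 nM, and compound 3 `Nc1cc(N)c2nc(-c3ccccc3)c(Sc3ccc(Cl)c(Cl)c3)nc2c1` gives 7080 nM. Compound 1 thus stands second highest of the three numbers, but its gaps to compound 2 and to compound 3 both lie within the scatter, so no order among them can be claimed.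

Compound 4 `COc1ccc(CNc2nc3cc(N)cc(N)c3nc2-c2ccccc2)cc1` has not been measured. It differs from compound 1 in one place: 4-methoxyphenyl in place of 3,4-dichlorophenyl on a saturated chain carbon bound to a nitrogen on an aromatic ring

Among the compounds with values here, only one measured step bears on this change, and only loosely: a 2.9-fold lower number from compound 2 to compound 3 (0.46 log units; beyond the scatter). That step sits on a sulfur rather than on the saturated chain carbon, and it trades a 4-fluorophenyl rather than a 4-methoxyphenyl, so it is a distant guide. Taken at face value, it suggests that losing the 3,4-dichlorophenyl tends toward a higher number. In this assay compound 4 is therefore expected to show a 1.6-fold higher number from compound 1 to compound 4 (0.21 log units; within the scatter), a modest rise. The estimate for compound 4 is 22000 nM, with a range from 8000 nM to 60000 nM.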

Compound 4, concentration for 50% growth inhibition: 22900 nM
Compound 4: the middle estimate sits 1.0-fold (0.02 log units) below what was measured, within the range that was stated.
By their numbers in this assay, from the lowest: compounds 3, 1, 2 and 4 (each within the scatter of the next, the first and the last beyond it).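

Within the data shown here, at this position, the saturated chain carbon bound to a nitrogen on an aromatic ring, the first direct reading in this assay is a 1.7-fold higher number from compound 1 to compound 4 (0.23 log units; within the scatter), and this step lies within the scatter. Compounds 1 and 4 therefore cannot be told apart, even though 4-methoxyphenyl brings one hydrogen-bond acceptor and no chlorine in place of 3,4-dichlorophenyl, with the same count of heavy atoms. No measurement shown explains this result.

A single pair cannot show whether other groups on this carbon would give a difference beyond the scatter, such as a carboxylic acid, an amine or a longer chain ending in the same rings. On these data alone, it also remains open how 4-methoxyphenyl would behave on the sulfur of compounds 2 and 3.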